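A few compounds are considered here, and "the series" means these few. Any claim that something is new, unique, unknown or untested is made for them only; others in the source may bear on it.

Measured so far:
Compound 1, `O=C(Nc1ccc(Oc2ccnc3[nH]ccc23)cc1)c1cn(-c2ccc(F)cc2)c2ccccc2c1=O` — 390 nM
Compound 2, `O=C(Nc1ccc(Oc2ccnc3[nH]ccc23)c(F)c1)c1cn(-c2ccc(F)cc2)c2ccccc2c1=O` — 290 nM

Of the compounds shown here, two share a core and have been tested in a functional assay on A549 cells (Homo sapiens) for inhibition, read by MTT assay, with a stated time of 72 h; a lower number here means a stronger inhibitor, a higher number a weaker inhibitor. Compound 1 gives 390 nM in this assay. Compound 2 carries a fluoro in place of a hydrogen on an aromatic carbon, and in this assay compound 2 gives 290 nM. For the measured compounds named here, the one step between them, a 1.3-fold lower number from compound 1 to compound 2 (0.13 log units; within the scatter), lies within the scatter, so the two values cannot be told apart, and compound 2 simply has the lower of the two numbers.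

Compound 3, `O=C(Nc1ccc(Oc2ccnc3[nH]ccc23)c(F)c1)c1cn(-c2ccc(F)c(Cl)c2)c2ccccc2c1=O`, has not yet been measured. It differs from compound 2 in one place: chloro in place of hydrogen on an aromatic carbon. Going by the values given here, the only measured step available, a 1.3-fold lower number from compound 1 to compound 2 (0.13 log units; within the scatter), concerns a different ring and a different halogen, so it bears on this change only loosely; it shows that one added halogen on an aryl ring of this core left the number within the scatter. On that basis the step of a 1.2-fold lower number from compound 2 to compound 3 (0.06 log units; within the scatter) is expected to stay within the scatter as well, in no clear direction. For compound 3 the estimate in this assay is 250 nM, with a range from 100 nM to 700 nM.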

Compound 3, half-maximal inhibitory concentration: 2150 nM
Estimate against measurement, compound 3: 8.6-fold (0.93 log units) below, outside the stated range (above it).
By their numbers in this assay, from the lowest: compounds 2 and 1 (each within the scatter of the next); then compound 3.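

In this assay, the change from 4-fluorophenyl to 3-chloro-4-fluorophenyl gives a 7.4-fold higher number from compound 2 to compound 3 (0.87 log units; beyond the scatter) and is the only step among these compounds that lies beyond the scatter. It shows that this place on the ring, ortho to a fluoro group and meta to a large group, does not tolerate every halogen equally: a single chlorine atom here raises the number, whereas the fluoro added on a different ring, with a 1.3-fold lower number from compound 1 to compound 2 (0.13 log units; within the scatter) as its step, produced no change that can be told from the scatter. No measurement on hand explains why the chloro has this effect.

The compounds shown leave open whether the higher number belongs to chloro alone or would follow other groups at this place, such as a fluoro, a methyl or a methoxy. They also leave open whether the same chloro would give a step of similar size on the core of compound 1, which lacks the fluoro that compound 2 and compound 3 carry on the other ring.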